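A few compounds are considered here, and "the series" means these few. Any claim that something is new, unique, unknown or untested is made for them only; others in the source may bear on it.

Measured so far
- compound 1, `COc1ccc2oc(=O)c(-c3ccc(Br)nn3)cc2c1`: 560 nM
- compound 2, `COc1ccc(-c2cc3cc(C)ccc3oc2=O)nn1`: 17600 nM

In an assay on cells for inhibition of Amine oxidase [flavin-containing] B (Homo sapiens), read by fluorescence and Amplex Red, with a stated time of 15 min (a higher number here means a weaker inhibitor, a lower number a stronger inhibitor), compound 1 gives the lower of the two numbers and compound 2 the higher one; the gap between them lies beyond the scatter, so compound 2 is the weaker inhibitor of the two. The two structures differ in more than one place, so the numbers alone say only that much.

Compound 3, `COc1ccc2oc(=O)c(-c3ccc(OC)nn3)cc2c1`, has not been measured. It differs from compound 2 in one place: methoxy in place of methyl on an aromatic carbon. With this change the substituent on the fused core of compound 3 matches that of compound 1, while the group on the other ring stays as in compound 2. Going by the values given here, no step between measured compounds isolates this change.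

The expectation for compound 3 is a lower number than that of compound 2, a step of moderate size, given as a 5.0-fold lower number from compound 2 to compound 3 (0.70 log units; beyond the scatter) in this assay. Compound 3 is estimated at 3500 nM, with a range from 800 nM to 14000 nM.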

Compound 3, half-maximal inhibitory concentration: 11100 nM
Compound 3: the middle estimate sits 3.2-fold (0.50 log units) below what was measured, and the stated range covers the measured number.
By their numbers in this assay, from the lowest: compound 1; then compounds 3 and 2 (each within the scatter of the next).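

In this assay, methoxy in place of methyl on the carbon-only aromatic ring of the fused system gives a 1.6-fold lower number from compound 2 to compound 3 (0.20 log units; within the scatter) and so does not separate the two groups at this position. Methoxy in place of bromo on the other ring gives a 20-fold higher number from compound 1 to compound 3 (1.30 log units; beyond the scatter) and is the only single-place step here beyond the scatter, which makes that ring the one place in these compounds where a change has been seen to move the number. No measurement of any property of these compounds bears on either step.

Going by these compounds, with only methyl and methoxy compared on the fused system, it remains open whether this position stays as flat for a longer chain such as ethoxy or butoxy, for an amine or for a carboxylic acid. On the other ring, only bromo and methoxy can be compared directly, so chloro, an amine or a plain hydrogen there would be needed to show whether bromo is a special case or one point on a wider trend.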